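A few compounds are considered here, and "the series" means these few. Any claim that something is new, unique, unknown or untested is made for them only; others in the source may bear on it.

Measured in a functional assay on HepG2 cells (Homo sapiens) for cytotoxicity, read by sulforhodamine B assay, with a stated time of 48 h; on this read-out lower numbers stand for stronger inhibition and higher numbers for weaker inhibition:
- compound 1 `N#Cc1c(-c2ccc(Cl)cc2)cc(-c2ccc(Cl)cc2)n(CC2CO2)c1=O`: 6.2 ug/mL
- compound 2 `N#Cc1c(-c2ccc(Cl)cc2)cc(-c2ccc(Cl)cc2)n([C@@H]2O[C@H](CO)[C@@H](O)[C@H](O)[C@H]2O)c1=O`: 16.1 ug/mL

Compound 2 carries the higher of the two numbers. Compound 3 `C#CCn1c(-c2ccc(Cl)cc2)cc(-c2ccc(Cl)cc2)c(C#N)c1=O` differs from it as follows: propargyl in place of 3,4,5-trihydroxy-6-(hydroxymethyl)oxan-2-yl on an aromatic nitrogen. Among the measured compounds shown here, one measured step bears on this nitrogen: a 2.6-fold higher number from compound 1 to compound 2 (0.41 log units; beyond the scatter). That step is modest, and it came with the arrival of the same group that now leaves. Going by these compounds, with that group gone, a modest step down in this assay is expected, though propargyl itself is untested here. The expected change is a 2.0-fold lower number from compound 2 to compound 3 (0.30 log units; within the scatter). For compound 3 the estimate is 8 ug/mL, with a range of 3.5 ug/mL to 18 ug/mL.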

Compound 3, half-maximal inhibitory concentration: 18.3 ug/mL
Compound 3: middle estimate off by 2.3-fold (0.36 log units), on the low side, and the stated range ends below it.
By their numbers in this assay, from the lowest: compound 1; then compounds 2 and 3 (each within the scatter of the next).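

In this assay, swapping the 3,4,5-trihydroxy-6-(hydroxymethyl)oxan-2-yl group for propargyl on the aromatic nitrogen gives a 1.1-fold higher number from compound 2 to compound 3 (0.06 log units; within the scatter), so removing the ring and its 4 hydrogen-bond donors does not separate these two compounds. The gap to the (oxiran-2-yl)methyl compound remains, with a 3.0-fold higher number from compound 1 to compound 3 (0.47 log units; beyond the scatter), leaving compound 1 alone at the low end of the three. Nothing measured here accounts for this.

Going by these compounds, whether an amine, a carboxylic acid or a longer alkyl chain on this nitrogen would read with compound 1 or with compounds 2 and 3 remains open.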